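A few compounds are considered here, and "the series" means these few. Any claim that something is new, unique, unknown or untested is made for them only; others in the source may bear on it.

Three compounds have so far been measured in an assay on isolated protein for inhibition of mitogen-activated protein kinase kinase kinase 20 (Homo sapiens), read by polymerase chain reaction, with a stated time of 1 h; a lower number here means a stronger inhibitor, a higher number a weaker inhibitor:

Compound 1 `O=S(=O)(NCCCNc1nccc(-c2c(-c3cccc(O)c3)nc3sccn23)n1)c1cccc(F)c1`: 10300 nM
Compound 2 `O=S(=O)(NCCNc1nccc(-c2c(-c3cccc(O)c3)nc3sccn23)n1)c1ccc(F)cc1`: 7580 nM
Compound 3 `COc1cccc(-c2nc3sccn3c2-c2ccnc(NCCNS(=O)(=O)c3ccc(C(F)(F)F)cc3)n2)c1`: 8110 nM

All three share the same core and differ only in the side chain that hangs from the pyrimidine nitrogen and in the substituent on the phenyl ring. The number for compound 1 is the largest of the three, but the gaps to compound 3 and to compound 2 both fall within the usual scatter, so the three cannot really be told apart.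

Compound 4 `COc1cccc(-c2nc3sccn3c2-c2ccnc(NCCCNS(=O)(=O)c3cccc(F)c3)n2)c1` has not yet been measured. It differs from compound 1 in one place: methyl in place of hydrogen on an oxygen on an aromatic ring, that is, hydroxy becomes methoxy and 3-hydroxyphenyl becomes 3-methoxyphenyl.

Among the measured compounds shown here, no measured pair isolates exactly this change. For the measured compounds named here, the one single-point step recorded, a 1.4-fold lower number from compound 1 to compound 2 (0.13 log units; within the scatter), concerns the sulfonamide end of the chain and stayed within the scatter. Compound 3 already carries the methoxy group, though it also differs from compound 1 in the chain and the sulfonyl aryl; its value and that of compound 1 lie within the scatter of each other. On that basis the expected step is a 1.1-fold lower number from compound 1 to compound 4 (0.06 log units; within the scatter), nothing beyond the scatter. Compound 4 is therefore estimated at 9000 nM, with a range from 4000 nM to 20000 nM.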

Compound 4, half-maximal inhibitory concentration: 11300 nM
Estimate against measurement, compound 4: 1.3-fold (0.10 log units) below; the range from low to high includes it.
By their numbers in this assay, from the lowest: compounds 2, 3, 1 and 4 (each within the scatter of the next).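

In this assay, among the compounds shown here, the step from hydroxy to methoxy gives a 1.1-fold higher number from compound 1 to compound 4 (0.04 log units; within the scatter), the first reading of this change with the rest of the molecule held constant. Placing a methyl in place of hydrogen on this oxygen therefore leaves two compounds that cannot be told apart, so the hydrogen can be exchanged here without a measurable difference in this assay. No separate measurement bears on why the number holds steady.

Going by these compounds, it remains open whether a larger ether such as ethoxy or benzyloxy, or an amine or a carboxylic acid in place of the hydroxy, would give a step beyond the scatter. The compounds also leave open whether the same methyl swap would read alike on the side chain of compound 2.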